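A few compounds are considered here, and "the series" means these few. Any claim that something is new, unique, unknown or untested is made for them only; others in the source may bear on it.

Compound 1 `Oc1ccc(-c2cc(-c3ccc(F)cc3)cc(-c3cccc(O)c3)n2)cc1` and compound 2 `Oc1ccc(-c2cc(-c3ccc(F)cc3)cc(-c3ccc(O)cc3)n2)cc1` share one core and differ only in one hydroxyphenyl group. In a functional assay on HeLa cells (Homo sapiens) for inhibition (a higher number here means a weaker inhibitor, a lower number a stronger inhibitor), compound 1 gives 8080 nM, and compound 2 gives 8680 nM; the move from compound 1 to compound 2 is a 1.1-fold higher number from compound 1 to compound 2 (0.03 log units; within the scatter), so the two numbers lie within the scatter of each other and compound 1 can be placed no more precisely than alongside compound 2.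

Compound 3 `Oc1ccc(-c2cc(-c3ccccc3C(F)(F)F)cc(-c3cccc(O)c3)n2)cc1` is reached from compound 1 by a change at a different place: 2-(trifluoromethyl)phenyl in place of 4-fluorophenyl on an aromatic carbon. For the measured compounds named here, neither measured compound varies this position, so the only measured step, the one from compound 1 to compound 2, touches a group that is kept unchanged here and gives no direct guide. Going by the values given here, the one step known was within the scatter, and nothing in the data argues for a step beyond the scatter in this assay in either direction for the present exchange. Compound 3 is therefore expected to give about 8000 nM, with a range from 2500 nM to 25000 nM, which corresponds to an estimated step of a 1.0-fold lower number from compound 1 to compound 3 (0.00 log units; within the scatter) from compound 1 to compound 3.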

Compound 3, half-maximal inhibitory concentration: 17400 nM
Compound 3: middle estimate off by 2.2-fold (0.34 log units), on the low side; the range from low to high includes it.
By their numbers in this assay, from the lowest: compounds 1, 2 and 3 (each within the scatter of the next, the first and the last beyond it).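

Placing 2-(trifluoromethyl)phenyl in place of 4-fluorophenyl, on the aromatic carbon opposite the ring nitrogen, gives a 2.2-fold higher number from compound 1 to compound 3 (0.33 log units; beyond the scatter) in this assay. For the compounds shown here, this is the first step in the set to lie beyond the scatter, though only modestly, whereas the exchange of hydroxyphenyl groups, a 1.1-fold higher number from compound 1 to compound 2 (0.03 log units; within the scatter), did not, so the number in this assay does respond to the aryl group at this position, and the response is towards a weaker inhibitor for this one exchange. Nothing available explains the shift, as no independent measurement bears on this change.

The entering group differs from the leaving one both in its substituent and in where that substituent sits on the phenyl ring, and a 4-(trifluoromethyl)phenyl or a 2-fluorophenyl group at this position would be needed to tell those two changes apart. Also open, as far as these compounds go, is whether a stronger inhibitor can be reached here at all, and how the position would answer to a group of another kind, such as an amine or a carboxylic acid on the phenyl ring.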